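The compounds below may be only part of what the source reports. "The series", "measured", "known", "first", "only" and "open" are said of these compounds alone.

Compound 1 `COc1ccc2c(c1)NC(=O)CN2c1nc(OCC2CC2)nc2ccccc12` and compound 2 `CCCCNc1nc(N2CC(=O)Nc3cc(OC)ccc32)c2ccccc2n1` are the two measured compounds. In a functional assay on A549 cells (Homo sapiens) for inhibition, read by sulforhodamine B assay, with a stated time of 48 h (on this read-out lower numbers stand for stronger inhibition of growth and higher numbers for weaker inhibition of growth), compound 1 gives 15.8 nM, and compound 2 gives 5.25 nM.

Within the data shown here, compound 2 holds the lowest number of the two, and the one step measured, a 3.0-fold lower number from compound 1 to compound 2 (0.48 log units; beyond the scatter), shows that it sits beyond the scatter from compound 1. Compound 3 `COc1ccc2c(c1)NC(=O)CN2c1nc(NC2CCCC2)nc2ccccc12` differs from compound 2 by cyclopentyl in place of butyl on a nitrogen on an aromatic ring. Among the measured compounds shown here, no measured step bears on this exchange: the step from compound 1 to compound 2 swaps the group on the ring carbon, not the alkyl on the nitrogen. Without a comparable step, compound 3 is expected to give 5.5 nM in this assay, within 2 nM to 16 nM, a change of a 1.0-fold higher number from compound 2 to compound 3 (0.02 log units; within the scatter) that is expected to stay within the scatter.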

Compound 3, concentration for 50% growth inhibition in the A549 assay: 7.67 nM
For compound 3 the middle estimate is 1.4-fold (0.14 log units) below the measured one; the range from low to high includes it.
By their numbers in the A549 assay, from the lowest: compounds 2 and 3 (each within the scatter of the next); then compound 1.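

In the A549 assay, a ring can take the place of the open chain on a nitrogen on an aromatic ring with no change beyond the scatter: a 1.5-fold higher number from compound 2 to compound 3 (0.16 log units; within the scatter). The cyclopentylamino group also keeps an edge over cyclopropylmethoxy on the aromatic carbon: a 2.1-fold lower number from compound 1 to compound 3 (0.31 log units; beyond the scatter). In a physicochemical assay for lipophilicity, read by HPLC, measured as octanol-water partition, tested at 1 mg/mL (a higher number here means a more lipophilic compound, a lower number a more polar compound), compound 2 gives 3.91 and compound 3 gives 2.33, so the exchange that leaves growth inhibition within the scatter moves the partition coefficient well beyond it.

From the compounds shown here alone, how a cyclohexyl ring, a longer chain or a terminal amine on this nitrogen would fare in the A549 assay remains open.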